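This account rests on a few compounds, and the source may have more. Where it says the series, first, only, none or still open, it means among the compounds named here.

Measured compounds:
- compound 1, `CCCCCCCCC[C@]1(CO)NC[C@@H](O)[C@@H]1O`, giving 0%
- compound 2, `Cc1ccc([C@@]2(CO)NC[C@H](O)[C@H]2O)cc1`, giving 3.3%
- compound 3, `OC[C@]1(c2c(F)c(F)c(F)c(F)c2F)NC[C@H](O)[C@H]1O`, giving 0%

All three compounds share a small nitrogen-containing ring carrying a hydroxymethyl group and two hydroxyl groups, and they differ in the substituent on the carbon that bears the hydroxymethyl group. In an assay on isolated protein for inhibition of tissue alpha-L-fucosidase (Bos taurus), tested at 1000 uM (on this read-out lower numbers stand for less inhibition and higher numbers for more inhibition at the one concentration tested (going by the name of the read-out)), compound 1 gives 0%, compound 2 gives 3.3% and compound 3 gives 0%. Compound 3 thus sits at the same reading as compound 1, and the gap to compound 2 is within the scatter of repeated measurements, so nothing separates the three on this read-out: none of them shows inhibition worth speaking of at the single concentration tested.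

Compound 4, `OC[C@@]1(c2c(F)c(F)c(F)c(F)c2F)NC[C@@H](O)[C@@H]1O`, has not yet been measured in this assay. It is the mirror image of compound 3: the two compounds have the same atoms and bonds and differ only in configuration as drawn: 3 of 3 stereo elements differ (all stereocentres are inverted: mirror images); a stereocentre at a saturated ring carbon is drawn S in compound 3 and R in compound 4; a stereocentre at a saturated ring carbon is drawn S in compound 3 and R in compound 4; a stereocentre at a saturated ring carbon is drawn S in compound 3 and R in compound 4. Within the data shown here, no measured pair in this set tests what inverting all three stereocentres does, so no step size can be read off. Since compound 3 gives 0% and every compound in the set sits near zero, the change from compound 3 to compound 4 is expected to be a number 2 percentage points higher from compound 3 to compound 4 (within the scatter), that is, no step beyond the scatter in either direction. Compound 4 is therefore estimated to give 2%, with a plausible range from -8% to 15%.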

Compound 4, a percentage reported as inhibition, at one concentration (the size of the read-out at that concentration, not a potency): 3.8%
Estimate against measurement, compound 4: 1.8 percentage points below; measured number inside the range.
By their numbers in this assay, from the lowest: compounds 1, 3, 2 and 4 (each within the scatter of the next).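

Among these compounds, compounds 3 and 4 are the first pair in this set that can be compared directly, and the comparison rests on one thing: the fact that compounds 3 and 4 differ only in the configuration as drawn. In this assay, among the compounds shown here, inverting all three stereocentres gives a number 3.8 percentage points higher from compound 3 to compound 4 (within the scatter), so at the single concentration tested this change leaves the reading inside the scatter. With this substituent, then, neither mirror-image form stands apart from the other, and neither shows inhibition worth speaking of on this read-out.

Both readings sit near zero, so this pair cannot tell whether configuration would matter in a compound with a reading clearly above zero, where a difference between mirror images would have room to show. As far as these compounds go, it also remains open whether an amine or a carboxylic acid in place of this substituent, on the carbon that bears the hydroxymethyl group, would give a reading clear of the scatter in either configuration, and how the mirror-image forms of compound 1 and compound 2 would read.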